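Trading a methoxy for hydrogen in compound 4

A few compounds are considered here, and "the series" means these few. Any claim that something is new, unique, unknown or untested is made for them only; others in the source may bear on it.

Compound 1 `COc1ccccc1/C=C/C(=O)OC/C=C/c1cc(OC)c(OC)cc1OC`: 101 umol/kg
Compound 2 `COc1cc(OC)c(OC)cc1/C=C/COC(=O)/C=C/c1ccc(OC)c(OC)c1`: 140 umol/kg
Compound 3 `COc1cc(OC)c(OC)cc1/C=C/COC(=O)/C=C/c1cc(OC)c(OC)c(OC)c1OC`: 65.1 umol/kg

All three numbers come from a functional assay on the whole organism (strain Kunming) with Mus musculus as the target, with a stated time of 0.5 h; a lower number here means that less compound is needed, a higher number that more compound is needed for the effect. Compound 3 holds the lowest of the three numbers, at 65.1 umol/kg. Its gap to compound 1 lies within the usual scatter, while its gap to compound 2 lies beyond it.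

The next compound is compound 4 `COc1cc(OC)c(OC)cc1/C=C/COC(=O)/C=C/c1cc(OC)c(OC)c(OC)c1`, which has hydrogen in place of methoxy on an aromatic carbon of compound 3: hydrogen in place of methoxy on an aromatic carbon.

Among the measured compounds shown here, only one measured step links two compounds that differ in a single place: a 1.4-fold higher number from compound 1 to compound 2 (0.14 log units; within the scatter). It also alters methoxy groups on an aromatic ring, but it is not the same change, so it offers only loose guidance. Its size is small, and it stays within the scatter. The three values show no simple trend with the number of methoxy groups, and compound 1 goes against any such trend.

In this assay, no step beyond the scatter is therefore expected, with at most a slight drift toward compound 2 at 140 umol/kg. The expected step is a 1.4-fold higher number from compound 3 to compound 4 (0.14 log units; within the scatter). For compound 4 the estimated value is 90 umol/kg, with an expected range from 42 umol/kg to 190 umol/kg.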

Compound 4, dose for half-maximal effect: 74.7 umol/kg
Estimate against measurement, compound 4: 1.2-fold (0.08 log units) above; the measured number falls inside the stated range.
By their numbers in this assay, from the lowest: compounds 3, 4, 1 and 2 (each within the scatter of the next, the first and the last beyond it).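

In this assay, the methoxy on the aromatic carbon ortho to a large group can be exchanged for hydrogen with a 1.1-fold higher number from compound 3 to compound 4 (0.06 log units; within the scatter), so the numbers do not separate these two compounds and this methoxy group shows no measurable weight of its own. The second single change on the same ring, methoxy in place of hydrogen on an aromatic carbon, gives a 1.9-fold lower number from compound 2 to compound 4 (0.27 log units; within the scatter) and so also stays inside the usual spread between repeated measurements. Taken together, compounds 2, 3 and 4 form a short row on one ring in which neither single step can be read as a real change, and no separate measurement is available to explain these small steps.

The compounds shown carry only methoxy or hydrogen at this position, so it remains open whether a group of another kind there, such as an amine or a carboxylic acid, would shift the number beyond the scatter. Also open, on these data alone, is how the number would respond to a change away from this ring, for example an amide in place of the ester in the shared core.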